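Chain length at the amide nitrogen in vitamin D receptor agonists

The source may report more compounds than this note shows. Statements on the series, on what has been measured and on what is new or still open speak of the compounds shown alone.

Of the compounds shown here, three sharing one core have been measured in an assay on HL-60 cells for agonist activity at vitamin D3 receptor (Homo sapiens), read by microscopy, with a stated time of 96 h; on this read-out lower numbers stand for an effect already at smaller amounts and higher numbers for an effect only at larger amounts of compound. Compound 1 `CCn1c(C(=O)NCCCN(C)C)ccc1C(CC)(CC)c1ccc(OCC(=O)C(C)(C)C)c(C)c1` gives 96 nM. Compound 2 `CC[C@@H](C)[C@H](NC(=O)c1ccc(C(CC)(CC)c2ccc(OCC(O)C(C)(C)C)c(C)c2)n1CC)C(=O)OC` gives 26 nM. Compound 3 `CCn1c(C(=O)NCCN(C)C)ccc1C(CC)(CC)c1ccc(OCC(O)C(C)(C)C)c(C)c1` gives 14 nM, the lowest of the three numbers, though its gap to compound 2 lies within the scatter; only compound 1 stands clearly higher, and compound 1 differs from compound 3 in more than one place. Among the compounds with values here, the measured step of a 1.9-fold lower number from compound 2 to compound 3 (0.27 log units; within the scatter) is the only one that changes the group on the amide-type nitrogen, and it stayed within the scatter.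

Compound 4 `CCn1c(C(=O)NCCCN(C)C)ccc1C(CC)(CC)c1ccc(OCC(O)C(C)(C)C)c(C)c1` differs from compound 3 by (dimethylamino)methyl in place of dimethylamino on a saturated chain carbon, two bonds along the chain from an amide-type nitrogen. Within the data shown here, the one measured step at this position, from compound 2 to compound 3, was small, so the step from compound 3 to compound 4 in this assay is expected to be a 1.4-fold higher number from compound 3 to compound 4 (0.15 log units; within the scatter), no more than the scatter. Compound 4 is therefore estimated at 20 nM, with a range from 7 nM to 60 nM.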

Compound 4, half-maximal effective concentration: 37 nM
The estimate for compound 4 lay 1.9-fold (0.27 log units) below the measured number; the measured number falls inside the stated range.
By their numbers in this assay, from the lowest: compounds 3, 2 and 4 (each within the scatter of the next, the first and the last beyond it); then compound 1.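

In this assay, within the data shown here, 3-(dimethylamino)propyl in place of 2-(dimethylamino)ethyl on the amide-type nitrogen gives a 2.6-fold higher number from compound 3 to compound 4 (0.42 log units; beyond the scatter), the first step at this nitrogen to pass the scatter, so the number does respond to the length of this chain. Replacing 1-(methoxycarbonyl)-2-methylbutyl with 3-(dimethylamino)propyl on the same nitrogen gives a 1.4-fold higher number from compound 2 to compound 4 (0.15 log units; within the scatter), so these two quite different groups cannot be told apart here. With the 3-(dimethylamino)propyl chain held fixed, 1-hydroxy-2,2-dimethylpropyl in place of (tert-butyl)carbonyl gives a 2.6-fold lower number from compound 1 to compound 4 (0.41 log units; beyond the scatter), showing that this second position also affects the number.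

Nothing shown explains why either change moves the number. Still open, as far as these compounds go, is how a longer chain, such as 4-(dimethylamino)butyl, or a chain ending in a carboxylic acid or a morpholine would read.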